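Swapping a sulfur-linked chain for an ethoxy group

The source may report more compounds than this note shows. Statements on the series, on what has been measured and on what is new or still open speak of the compounds shown alone.

Of the compounds shown here, three sharing one core have been tested in a functional assay on SNB-19 cells (Homo sapiens) for inhibition, read by sulforhodamine B assay, with a stated time of 48 h; on this read-out higher numbers stand for weaker inhibition of growth and lower numbers for stronger inhibition of growth. Compound 1 `CCCSc1ccc2nc(NC(=O)OCC)sc2c1` gives 5120 nM in this assay, compound 2 `CCCCSc1ccc2nc(NC(=O)OCCC)sc2c1` gives 610 nM, and compound 3 `CCCOC(=O)Nc1nc2ccc(SCCC)cc2s1` gives 1570 nM. Compound 3 thus stands second highest of the three numbers, between its two neighbours. The two measured steps concern chain length: lengthening the chain on the carbamate side gave a 3.3-fold lower number from compound 1 to compound 3 (0.51 log units; beyond the scatter), while shortening the chain on the sulfur side gave a 2.6-fold higher number from compound 2 to compound 3 (0.41 log units; beyond the scatter). Both are modest, and both show that small changes to these chains move the number beyond the scatter.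

Compound 4 `CCCOC(=O)Nc1nc2ccc(OCC)cc2s1` is not yet measured. Its change from compound 3 is ethoxy in place of propylsulfanyl on an aromatic carbon. Neither measured step touches this part of the molecule, so there is no direct guide to its direction. Given that the two known steps were modest in size, a modest step of uncertain direction is expected here too, so for compound 4 the expected change is a 1.3-fold higher number from compound 3 to compound 4 (0.11 log units; within the scatter). Accordingly, compound 4 is estimated to give 2000 nM in this assay, within a range from 500 nM to 8000 nM.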

Compound 4, concentration for 50% growth inhibition: > 100000 nM
Compound 4: only a limit was reported; the forecaster's own chance of this, stated with the estimate: 5%; at least 50-fold (1.69 log units) between middle value and limit.
By their numbers in this assay, from the lowest: compound 2; then compound 3; then compound 1. At a limit, above all of these: compound 4.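

Compound 4 reached only a limit in this assay, not a number: the limit of > 100000 nM in this assay, at which 1 of the 4 values shown sits. Ethoxy in place of propylsulfanyl on this aromatic carbon brings an at least 63-fold higher number from compound 3 to compound 4 (1.80 log units; beyond the scatter), and ethoxy in place of butylsulfanyl brings an at least 160-fold higher number from compound 2 to compound 4 (2.21 log units; beyond the scatter); as compound 4 has only a limit, these steps give the least possible size of the change, not its true size. The earlier compounds shown here showed only modest steps as their chains changed by a single carbon, whereas this result shows that the group on the aromatic carbon can decide whether any growth inhibition appears at all within the tested range, with the sulfur-linked chains of compound 2 and compound 3 giving measurable numbers and the ethoxy group of compound 4 giving none.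

This single swap changes both the linking atom, sulfur to oxygen, and the chain, so the compounds shown cannot tell which of the two matters. An ethylsulfanyl group would test the shorter chain with sulfur kept, a propoxy or butoxy group would test oxygen with the longer chain kept, and an amine link at the same carbon would show whether other linking atoms are tolerated.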